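The compounds below may be only part of what the source reports. "The series", "measured", "known", "first", "only" and "open" are said of these compounds alone.

Among the compounds with values here, in a physicochemical assay for solubility, measured as kinetic solubility, at pH 6.8 (a lower number here means a less soluble compound, a higher number a more soluble compound), compound 1 `Cc1cc(C(=O)Nc2cc(Oc3ccc4nc(NC(=O)C5CC5)nn4c3)ccc2C)n(C)n1` gives 53 ug/mL, the highest of the three numbers measured so far. Compound 3 `Cc1cc(C(=O)Nc2cc(Oc3ccc4nc(NC(=O)C5CC5)sc4n3)ccc2C)n(C)n1` stands nearest to it, giving 4.8 ug/mL in this assay, a gap that lies beyond the scatter of repeated measurements. Compound 2 `Cc1cc(C(=O)Nc2cccc(Oc3ccc4nc(NC(=O)C5CC5)cn4c3)c2)n(C)n1` stands furthest away, giving 0.73 ug/mL in this assay, again a gap well beyond the scatter. Compound 1 thus sits at the upper end of what this small set has shown.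

Compound 4 `Cc1nc(C(=O)Nc2cc(Oc3ccc4nc(NC(=O)C5CC5)nn4c3)ccc2C)c(C)s1` has not yet been measured. It differs from compound 1 in one place: 2,5-dimethyl-1,3-thiazol-4-yl in place of 1,3-dimethyl-1H-pyrazol-5-yl on a carbonyl carbon. Within the data shown here, no pair among the measured compounds carries this same change, so there is no measured step from which its size could be read directly. Across the three measured compounds the numbers spread widely with changes in the central part of the molecule, but that tells nothing about an exchange of the ring on the carbonyl carbon.

An expectation can still be stated. The step from compound 1 to compound 4 is expected to be a 2.9-fold lower number from compound 1 to compound 4 (0.47 log units; beyond the scatter), a modest move downward that may or may not clear the scatter. For compound 4 the expected value in this assay is therefore 18 ug/mL, with a range from 4 ug/mL to 55 ug/mL.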

Compound 4, solubility: 0.16 ug/mL
For compound 4 the middle estimate is 110-fold (2.05 log units) above the measured one; measured number below the stated range.
By their numbers in this assay, from the lowest: compound 4; then compound 2; then compound 3; then compound 1.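

Within the data shown here, the exchange of 1,3-dimethyl-1H-pyrazol-5-yl for 2,5-dimethyl-1,3-thiazol-4-yl on a carbonyl carbon is the first change in this set that can be read on its own, and in this assay it is a 330-fold lower number from compound 1 to compound 4 (2.52 log units; beyond the scatter) and counts as large. The earlier compounds shown here offered no step at all, whereas this one shows that the group on this carbonyl carbon alone, with the core of compound 1 left as it is, can move the number a long way, even though the two groups match in what is counted for them: heavy atoms, hydrogen-bond donors and hydrogen-bond acceptors. Nothing in the data shown explains why the number falls so far.

A single pair leaves open whether the same exchange would move the number as far on the cores of compound 2 and compound 3, so the step holds for the core of compound 1 alone. Also open, from the compounds shown here alone, is how other groups on this carbonyl carbon would read, such as a morpholine ring, a pyrazole without its methyl groups, or an open chain ending in an amine or a carboxylic acid.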